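The source may hold more compounds than are shown below. What is called first, only, known or untested is meant among the compounds shown, and "the series" means these compounds.

Of the compounds shown here, three built on one shared core have been measured in an ADME assay on BJ cells (Homo sapiens) for inhibition, read by fluorescence and resazurin assay, with a stated time of 72 h; on this read-out lower numbers stand for stronger inhibition of growth and higher numbers for weaker inhibition of growth. Compound 1 `Nc1ccccc1-c1ccc(Nc2nc(N[C@H]3CC[C@H](N)CC3)nc3c2ncn3C2CCCC2)cc1` gives 12500 nM. Compound 2 `N[C@H]1CC[C@H](Nc2nc(Nc3ccc(-c4cccs4)nc3)c3ncn(C4CCCC4)c3n2)CC1` gives 2940 nM. Compound 3 `COc1ccccc1-c1ccc(Nc2nc(N[C@H]3CC[C@H](N)CC3)nc3c2ncn3C2CCCC2)cn1` gives 6200 nM. Of these three numbers compound 3 holds the second highest; its closest neighbour is compound 1, whose value lies within the usual scatter of this kind of measurement, while compound 2 lies further off, beyond that scatter.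

Going by the values given here, only one single-site step among the measured compounds has been recorded: a 2.1-fold higher number from compound 2 to compound 3 (0.32 log units; beyond the scatter), a modest move. Compound 4 `COc1ccc(-c2ccc(Nc3nc(N[C@H]4CC[C@H](N)CC4)nc4c3ncn4C3CCCC3)cn2)cc1` differs from compound 3 by 4-methoxyphenyl in place of 2-methoxyphenyl on an aromatic carbon, in words 4-methoxyphenyl in place of 2-methoxyphenyl on an aromatic carbon. The recorded step concerns an exchange of one aromatic group for another, not the position of a methoxy group on a phenyl ring, so it gives no direct guide to this change. With nothing pointing either way, the expectation for compound 4 in this assay is a change no larger than the scatter, no change at the digits printed from compound 3 to compound 4 (within the scatter). The number expected for compound 4 is therefore 6200 nM, with a likely range from 2800 nM to 14000 nM.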

Compound 4, concentration for 50% growth inhibition: 7230 nM
For compound 4 the middle estimate is 1.2-fold (0.07 log units) below the measured one; the range from low to high includes it.
By their numbers in this assay, from the lowest: compound 2; then compounds 3, 4 and 1 (each within the scatter of the next).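

In this assay, moving the methoxy group around the phenyl ring, with 4-methoxyphenyl in place of 2-methoxyphenyl, gives a 1.2-fold higher number from compound 3 to compound 4 (0.07 log units; within the scatter). Going by these compounds alone, on this aromatic carbon next to the ring nitrogen, the methoxy shift therefore leaves no difference that can be told apart from ordinary assay variation, which the earlier compounds could not show because none of them compared two methoxy placements. Exchanging thiophen-2-yl for the other methoxyphenyl isomer gives a 2.5-fold higher number from compound 2 to compound 4 (0.39 log units; beyond the scatter), so both methoxyphenyl groups now stand apart from thiophen-2-yl, whereas earlier only the 2-methoxyphenyl group had been compared with it, and nothing available gives a reason for either result.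

These compounds leave open whether an unsubstituted phenyl ring would fall with the two methoxyphenyl compounds or with the thiophen-2-yl compound. They also leave open whether a hydroxyl group, an amine or a carboxylic acid on the phenyl ring, in place of the methoxy group, would prove as unresponsive to a change of position as the methoxy group does here.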